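The source may hold more compounds than are shown below. What is called first, only, known or untested is meant among the compounds shown, and "the series" means these compounds.

Measured so far in a functional assay on SK-BR-3 cells (Homo sapiens) for antiproliferative activity, read by MTT assay, with a stated time of 72 h; a lower number here means a stronger inhibitor, a higher number a weaker inhibitor:
compound 1 `CCN1CCN(c2cc(C)c3cc(NC(=O)c4cc(Cl)cc(Cl)c4)ccc3n2)CC1`, 2660 nM
compound 3 `Cc1cc(NCCN2CCN(C)CC2)nc2ccc(NC(=O)c3ccc(Cl)c(Cl)c3)cc12`, 2690 nM
compound 2 `Cc1cc(N(C)C)nc2ccc(NC(=O)c3ccc(Cl)c(Cl)c3)cc12`, for which the reading > 50000 nM is a limit of the assay and not a number.

Compound 1 holds the lowest of the two numbers in this assay; its nearest neighbour is compound 3, and the two values lie within the scatter of each other, so no order can be read between them. Among the compounds with values here, the one measured step is an at least 18-fold lower number from compound 2 to compound 3 (1.26 log units; beyond the scatter); it concerns the amine substituent on the shared core and leaves the amide side untouched. Among the three readings, the limit of > 50000 nM in this assay, at which 1 of the 3 values shown sits, is the only point at which a compound sits at the limit.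

Compound 4 `CCN1CCN(c2cc(C)c3cc(NC(=O)c4ccco4)ccc3n2)CC1` differs from compound 1 by furan-2-yl in place of 3,5-dichlorophenyl on a carbonyl carbon. Within the data shown here, no measured step touches the amide aryl group, so the expectation rests on the change alone. A weakening beyond the scatter is expected, of moderate size, giving a 3.4-fold higher number from compound 1 to compound 4 (0.53 log units; beyond the scatter). Compound 4 is thus estimated at 9000 nM, within a range from 2500 nM to 35000 nM.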

Compound 4, half-maximal inhibitory concentration: 37500 nM
Beside the measured number, compound 4's estimate is 4.2-fold (0.62 log units) below it, outside the stated range (above it).
By their numbers in this assay, from the lowest: compounds 1 and 3 (each within the scatter of the next); then compound 4. At a limit, above all of these: compound 2.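

In this assay, the amide aryl group proves to be a sensitive place on the shared core: furan-2-yl in place of 3,5-dichlorophenyl on the carbonyl carbon gives a large weakening (a 14-fold higher number from compound 1 to compound 4 (1.15 log units; beyond the scatter)). Within the data shown here, the earlier step concerned only the amine substituent (an at least 18-fold lower number from compound 2 to compound 3 (1.26 log units; beyond the scatter)), so this is the first reading showing that the amide side alone can also move the number beyond the scatter. Nothing at hand gives a cause for this step.

The change swaps a six-membered carbon ring carrying two chlorines for a five-membered ring with oxygen, and these features remain unseparated; an unsubstituted phenyl or a thiophen-2-yl on the same carbonyl would begin to divide them. Also open, from the compounds shown here alone, is whether the step holds with another amine on the core, such as a morpholine.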